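The compounds below may be only part of what the source reports. "The series", "measured", "known", "first", "only" and "open" are said of these compounds alone.

Of the compounds shown here, two that share a core have been tested so far, compound 1 (`COc1ccc(-c2nc3sc(-c4ccccc4)cn3n2)cc1`) and compound 2 (`Clc1ccc(-c2cn3nc(-c4ccccc4)nc3s2)cc1`). In a functional assay on KM12 cells (Homo sapiens) for inhibition, read by sulforhodamine B assay, with a stated time of 48 h, tested at 10 uM (a lower number here means less inhibition of growth, a higher number more inhibition of growth at the concentration tested), compound 1 gives 70%, while compound 2 gives 30%. Compound 2 therefore holds the lower of the two numbers, and its gap to compound 1 lies beyond the usual scatter of repeated measurements.

Compound 3 (`COc1ccc(-c2nc3sc(-c4ccc(Cl)cc4)cn3n2)cc1`) has not yet been measured. It differs from compound 2 by a single change, methoxy in place of hydrogen on an aromatic carbon, para to a large group. Compound 1 also carries a methoxy group, and its 70% is the only hint available. Among the measured compounds shown here, that hint is weak, since no measured pair here differs in just one place.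

A rise beyond the scatter in this assay is still expected, and the estimated change is a number 28 percentage points higher from compound 2 to compound 3 (beyond the scatter). Compound 3 is estimated to give 58%, with an expected range from 32% to 84%.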

Compound 3, percent growth inhibition at one concentration: 45.3%
Compound 3: middle estimate off by 12.7 percentage points, on the high side, within the range that was stated.
By their numbers in this assay, from the lowest: compound 2; then compound 3; then compound 1.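

In this assay, among the compounds shown here, this is the first comparison of compounds that differ in only one place, and putting methoxy in place of hydrogen on an aromatic carbon, para to a large group, increases growth inhibition (a number 15.3 percentage points higher from compound 2 to compound 3 (beyond the scatter)). The second comparison runs the other way: chloro in place of hydrogen on an aromatic carbon goes with less growth inhibition (a number 24.7 percentage points lower from compound 1 to compound 3 (beyond the scatter)), so within these three compounds, adding methoxy helps and adding chloro hurts, and compound 3 carries both groups. Nothing available explains why either change has this effect.

As far as these compounds go, each change is seen only once, so it remains open whether the methoxy step would keep its size on a compound without the chloro, or the chloro step on one without the methoxy. From the compounds shown here alone, it is also open how an amine, a hydroxy group or a longer chain such as ethoxy at the methoxy position would compare with methoxy and with hydrogen.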